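The source may report more compounds than this note shows. Statements on the series, on what has been measured and on what is new or still open speak of the compounds shown alone.

Compound 1: `COC(=O)N[C@H](C)c1nc2ccc(F)cc2s1`; in a physicochemical assay for lipophilicity, using the shake flask method, measured as octanol-water partition, with a stated time of 15 min (a lower number here means a more polar compound, a higher number a more lipophilic compound), compound 1 gives 2.5.
Compound 2: `CCOC(=O)N[C@H](C)c1nc2ccc(F)cc2s1`; in this assay compound 2 gives 4.2.

Going by the values given here, compound 2 stands at the higher of the two numbers measured so far, and the gap to compound 1 lies beyond the scatter. Among the compounds with values here, the only step measured, a number 1.70 log units higher from compound 1 to compound 2 (beyond the scatter), was large and came from lengthening the chain on the oxygen next to the carbonyl by one carbon.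

Compound 3, `CCCOC(=O)N[C@H](C)c1nc2ccc(F)cc2s1`, has not yet been measured in this assay. It differs from compound 2 by methyl in place of hydrogen on a saturated chain carbon, two bonds along the chain from an oxygen next to a carbonyl group. This is the same kind of change as the measured step, cut one bond further out along the chain, so that step is the one that bears on it. A rise beyond the scatter is therefore expected, though a somewhat smaller one than the step already seen; the expected step is a number 0.70 log units higher from compound 2 to compound 3 (beyond the scatter). Compound 3 is estimated at 4.9, with a range from 4.4 to 5.5.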

Compound 3, partition coefficient: 4.56
For compound 3 the middle estimate is 0.34 log units above the measured one; the measured number falls inside the stated range.
By their numbers in this assay, from the lowest: compound 1; then compound 2; then compound 3.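

Made one bond further out along the chain, the same kind of change still moves the number in this assay in the same direction, with a number 0.36 log units higher from compound 2 to compound 3 (beyond the scatter) set against a number 1.70 log units higher from compound 1 to compound 2 (beyond the scatter) for the first added methyl. The rise therefore continues along this chain, but the second step is modest where the first was large. Over both added methyl groups the total is a number 2.06 log units higher from compound 1 to compound 3 (beyond the scatter), and most of it comes from the first step.

As far as these compounds go, whether the rise would go on or level off with a longer chain such as butyl, and how a chain ending in an amine or a carboxylic acid would read, stays open. Nothing measured here explains why the second step is smaller than the first.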